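A small chain extension on a cytotoxicity-tolerant scaffold

This account rests on a few compounds, and the source may have more. Where it says the series, first, only, none or still open, it means among the compounds named here.

Compound 2 `CCCc1ccc(-c2ccc3ncc(-c4noc(C)n4)cc3c2)cc1` was tested in a functional assay on RD cells (Homo sapiens) for inhibition, read by luminescence and ATP content, with a stated time of 72 h; a higher number here means that more compound is tolerated, a lower number that less compound is tolerated. In this assay compound 2 gives > 7400 nM, which is a limit of the assay rather than a measured number. Two related compounds share its core. Compound 1 `CCCc1ccc(-c2ccc3ncc(C(=O)OCC)cc3c2)cc1` carries an ethoxycarbonyl group where compound 2 carries the 5-methyl-1,2,4-oxadiazol-3-yl group; in this assay compound 1 gives > 7400 nM, again a limit. Compound 3 `Cc1nc(-c2cnc3ccc(-c4ccccc4)cc3c2)no1` lacks the propyl group; in this assay compound 3 gives > 2500 nM, also a limit. The step that the two limits leave unreadable from compound 1 to compound 2 and the step that the two limits leave unreadable from compound 2 to compound 3 therefore both sit between limits, as the limit of > 7400 nM in this assay, at which 2 of the 3 values shown sit, and the limit of > 2500 nM in this assay, at which 1 of the 3 values shown sits, show. Compound 4 `CCCc1ccc(-c2ccc3ncc(-c4noc(CC)n4)cc3c2)cc1` differs from compound 2 by methyl in place of hydrogen on a saturated chain carbon bound to an aromatic carbon. Among the measured compounds shown here, no measured step bears readably on this change, and every compound shown sits at a limit, so compound 4 is expected to remain at or beyond the same limit, a step that the limit leaves unreadable from compound 2 to compound 4 being the estimate. Compound 4 is thus estimated at 10000 nM, in the range 5000 nM to 30000 nM.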

Compound 4, half-maximal cytotoxic concentration: > 7400 nM
Compound 4: a limit, no number; the forecaster's own chance of this, stated with the estimate: 80%; the middle value lies beyond the limit too.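

Among the compounds shown here, compound 4 gives only a limit in this assay, as do compound 1 and compound 2, and no step to compound 4 can be read. The compounds shown leave open the actual cytotoxic concentration of each, and whether going from methyl to ethyl alters it.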